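A few compounds are considered here, and "the series" means these few. Any claim that something is new, unique, unknown or untested is made for them only; others in the source may bear on it.

Three compounds have been measured in a functional assay on LOX IMVI cells (Homo sapiens) for cytotoxicity, read by sulforhodamine B assay, with a stated time of 48 h; on this read-out higher numbers stand for weaker inhibition of growth and lower numbers for stronger inhibition of growth:

Compound 1, `ClCc1ccccc1Cn1cnc2c(Cl)nc(Cl)nc21`, gives 150 nM.
Compound 2, `ClCc1ccccc1Cn1cnc2c(Cl)ncnc21`, gives 2130 nM.
Compound 3, `ClCc1cccc(Cn2cnc3c(Cl)ncnc32)c1`, gives 1950 nM.

Compound 2 and compound 1 differ in one place: chloro in place of hydrogen on an aromatic carbon. That change brings a 14-fold lower number from compound 2 to compound 1 (1.15 log units; beyond the scatter), a large step that lies well beyond the usual scatter of this kind of measurement. Compound 3 is built from the same atoms as compound 2, joined differently; the difference between the two cores is not broken down here. In this assay compound 3 and compound 2 give numbers that lie within the scatter of each other, so nothing can be said about an order between them.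

Compound 4, `ClCc1cccc(Cn2cnc3c(Cl)nc(Cl)nc32)c1`, has not yet been measured in this assay. It stands to compound 3 as compound 1 stands to compound 2: chloro in place of hydrogen on an aromatic carbon, at a place described in exactly the same words as the place of the earlier change, so this is the same change made on the core of compound 3. Because a 14-fold lower number from compound 2 to compound 1 (1.15 log units; beyond the scatter) was a large step, the step expected here is a 13-fold lower number from compound 3 to compound 4 (1.11 log units; beyond the scatter). Starting from the value of compound 3, compound 4 is therefore expected to give about 150 nM, most likely between 50 nM and 450 nM. This rests on a single measured pair, compound 2 and compound 1, so the expectation carries the uncertainty of a change seen only once.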

Compound 4, concentration for 50% growth inhibition: 1690 nM
Estimate against measurement, compound 4: 11-fold (1.05 log units) below, outside the stated range (above it).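

The new step is a 1.2-fold lower number from compound 3 to compound 4 (0.06 log units; within the scatter), so in this assay the added chloro gives two numbers that cannot be put in any order, and the large step seen on the other core does not appear here. Carrying this change from one core to the other therefore fails in this small series, and a step seen on one core could not be relied on for the other, as the two pairs set side by side make plain: the same change on two cores in this assay, a 14-fold lower number (1.15 log units; beyond the scatter) from compound 2 to compound 1 and a 1.2-fold lower number (0.06 log units; within the scatter) from compound 3 to compound 4, 12-fold (1.09 log units) apart, beyond the scatter of two such steps. This shows that the size of the step depends on which of these two cores carries the chloro, but it does not show why, and two pairs give no rule for any further core.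

The compounds shown leave open whether a different group on the same aromatic carbon, such as an amine or a methoxy group, would also give different steps on the two cores. They also leave open whether changing the rest of the molecule, for instance with a longer chain in place of the chloromethyl group, would bring back the large step or remove it on both cores.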